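A few compounds are considered here, and "the series" means these few. Any claim that something is new, unique, unknown or untested is made for them only; others in the source may bear on it.

Compound 1 `O=C(Nc1cccc(-n2cc(-c3ccncc3)c(-c3cc(O)cc(Cl)c3)n2)c1)Nc1ccc(Cl)c(C(F)(F)F)c1`: -73%
Compound 2 `COc1cc(Cl)cc(-c2nn(-c3cccc(NC(=O)Nc4cc(C(F)(F)F)cc(C(F)(F)F)c4)c3)cc2-c2ccncc2)c1`: -82%

Of the compounds shown here, two have been measured in a functional assay on UO-31 cells (Homo sapiens) for inhibition, read by sulforhodamine B assay, with a stated time of 48 h, tested at 100 uM; on this read-out higher numbers stand for a weaker effect at the one concentration tested and lower numbers for a stronger effect. In this assay compound 1 gives -73%, and compound 2 gives -82%. Compound 2 stands at the lower of the two numbers, but the gap to compound 1 lies within the usual scatter, so the two values show no difference that can be read as one. Among the compounds with values here, no pair of measured compounds differing in a single place is available, so no step size is known from measurement.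

Compound 3 `COc1cc(Cl)cc(-c2nn(-c3cccc(NC(=O)Nc4cccc(C(F)(F)F)c4)c3)cc2-c2ccncc2)c1` has not yet been measured in this assay. It differs from compound 2 in one place: hydrogen in place of trifluoromethyl on an aromatic carbon. Nothing in the measured pair bears directly on this change. The step of a number 12 percentage points higher from compound 2 to compound 3 (beyond the scatter) is expected to be small, if anything toward a weaker effect, and most likely not beyond the scatter. Compound 3 is therefore estimated at -70%, within a range from -95% to -30%.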

Compound 3, a percentage reported as activity, at one concentration (the size of the read-out at that concentration, not a potency): -20%
Compound 3: the middle estimate sits 50 percentage points below what was measured, and the stated range ends below it.
By their numbers in this assay, from the lowest: compounds 2 and 1 (each within the scatter of the next); then compound 3.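

In this assay, within the data shown here, replacing the trifluoromethyl group with hydrogen on this aromatic carbon gives a number 62 percentage points higher from compound 2 to compound 3 (beyond the scatter), the first measured single-place change. This position therefore matters to the read-out, and the other trifluoromethyl group, which both compounds carry on the same ring, does not preserve the effect of compound 2 once this one is gone. No available evidence explains the size of this step.

The compounds shown leave open whether the effect depends on trifluoromethyl itself or could also be carried at this carbon by a nitrile, a methyl group or an amine. They also leave open whether this step would be of similar size if the substituents elsewhere on the core were changed.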